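The source may hold more compounds than are shown below. What is called first, only, known or untested is meant among the compounds shown, and "the series" means these compounds.

Of the compounds shown here, three of a shared core have been measured in an assay on isolated protein for binding affinity to metabotropic glutamate receptor 2 (Homo sapiens); a lower number here means that less compound is needed, a higher number that more compound is needed for the effect. Compound 1 `CC1(C2CCCC2)Cc2cc(OCCCc3nn[nH]n3)c(Cl)c(Cl)c2C1=O` gives 5000 nM, compound 2 `CC1(C2CCCC2)Cc2cc(OCCCCCc3nn[nH]n3)c(Cl)c(Cl)c2C1=O` gives 761 nM, and compound 3 `CCCCC1(C2CCCC2)Cc2cc(OCc3ccc(-c4nn[nH]n4)cc3)c(Cl)c(Cl)c2C1=O` gives 1090 nM. Compound 2 has the lowest number of the three: its gap to compound 3 lies within the scatter, while compound 1 sits well beyond it. Among the measured compounds shown here, the only single-point step measured runs from compound 1 to compound 2, a 6.6-fold lower number from compound 1 to compound 2 (0.82 log units; beyond the scatter), so a longer chain to the tetrazole helped.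

Compound 4 `CC1(C2CCCC2)Cc2cc(OCc3ccc(C(=O)O)cc3)c(Cl)c(Cl)c2C1=O` is not yet measured. It differs from compound 2 in one place: 4-carboxyphenyl in place of 4-(2H-tetrazol-5-yl)butyl on a saturated chain carbon bound to an oxygen on an aromatic ring. For the measured compounds named here, no measured step bears directly on exchanging the tetrazole for a carboxylic acid or on replacing the flexible chain with a benzene ring; the nearest hint is compound 3, whose benzyl-linked tetrazole gives a number close to that of compound 2. Given this thin evidence, compound 4 is estimated at 2500 nM, with a plausible range from 600 nM to 10000 nM, which corresponds to an expected step of a 3.3-fold higher number from compound 2 to compound 4 (0.52 log units; beyond the scatter).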

Compound 4, half-maximal effective concentration: 892 nM
Compound 4: middle estimate off by 2.8-fold (0.45 log units), on the high side; the range from low to high includes it.
By their numbers in this assay, from the lowest: compounds 2, 4 and 3 (each within the scatter of the next); then compound 1.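

Putting 4-carboxyphenyl in place of 4-(2H-tetrazol-5-yl)butyl on a saturated chain carbon bound to an oxygen on an aromatic ring gives a 1.2-fold higher number from compound 2 to compound 4 (0.07 log units; within the scatter), so this assay does not tell these two groups apart. Against the 2-(2H-tetrazol-5-yl)ethyl group, the 4-carboxyphenyl group gives a 5.6-fold lower number from compound 1 to compound 4 (0.75 log units; beyond the scatter), which shows that a tetrazole is not needed at this position to reach the values of the longer tetrazole chain. No supporting data explain why the two groups read alike.

As far as these compounds go, both steps exchange the tetrazole and the chain together, so the share of each remains unknown. A 4-carboxybutyl chain would separate the two, and a methyl ester or primary amide in place of the carboxylic acid would test whether the acid itself matters.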